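Thiophen-2-yl for 5-chlorofuran-2-yl at the shared core

The source may report more compounds than this note shows. Statements on the series, on what has been measured and on what is new or still open speak of the compounds shown alone.

Going by the values given here, compound 2 `Nc1nc(-c2ccc(Cl)o2)nc2sc(CN3CCCC3)cc12` gives 710 nM in an assay on CHO-K1 cells for antagonist activity at adenosine receptor A1 (Homo sapiens), read by a beta-galactosidase reporter, with stated times of 15 min and 6 h (on this read-out lower numbers stand for stronger inhibition and higher numbers for weaker inhibition), the lowest of the two numbers so far; compound 1 `Nc1nc(-c2ccco2)nc2sc(CN3CCCC3)cc12` gives 6430 nM. Among the compounds with values here, the only measured step, a 9.1-fold lower number from compound 1 to compound 2 (0.96 log units; beyond the scatter), concerns the chloro on the five-membered ring. Within the data shown here, compound 3 `Nc1nc(-c2cccs2)nc2sc(CN3CCCC3)cc12` carries thiophen-2-yl in place of 5-chlorofuran-2-yl on an aromatic carbon, which drops the chloro while also exchanging the ring hetero atom, a combination no measured pair covers. Because a 9.1-fold lower number from compound 1 to compound 2 (0.96 log units; beyond the scatter) lay beyond the scatter, losing the chloro is expected to raise the number, with the hetero atom swap adding uncertainty. For compound 3 the expected step is a 4.2-fold higher number from compound 2 to compound 3 (0.63 log units; beyond the scatter). Compound 3 is thus estimated at 3000 nM in this assay, range 800 nM to 12000 nM.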

Compound 3, inhibition constant: > 10000 nM
Compound 3 ended at the assay's limit; the forecaster's own chance of this, stated with the estimate: 5%; middle value at least 3.3-fold (0.52 log units) away from the limit.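

In this assay compound 3 stands at a limit, not a number: the limit of > 10000 nM in this assay, at which 1 of the 3 values shown sits. Replacing 5-chlorofuran-2-yl with thiophen-2-yl on this carbon between two ring nitrogen atoms gives an at least 14-fold higher number from compound 2 to compound 3 (1.14 log units; beyond the scatter). Between the two rings without a chloro, thiophen-2-yl in place of furan-2-yl gives an at least 1.5-fold higher number from compound 1 to compound 3 (0.19 log units; that floor lies within the scatter), so this floor does not show whether those two rings differ.

Replacing 5-chlorofuran-2-yl with thiophen-2-yl changes the chloro and the ring hetero atom together, so their shares remain unseparated. A 5-chlorothiophen-2-yl group at this place would address that question.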